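Piperazin-1-yl step from compound 1 to compound 4

A few compounds are considered here, and "the series" means these few. Any claim that something is new, unique, unknown or untested is made for them only; others in the source may bear on it.

Measured in a functional assay on HL-60 cells (Homo sapiens) for antiproliferative activity, read by MTT assay (on this read-out lower numbers stand for stronger inhibition and higher numbers for weaker inhibition), all values being limits:
- compound 1 `O=C(N/N=C/c1ccccc1)c1cn(C2CC2)c2cc(N/N=C/c3ccccc3)c(F)cc2c1=O`: <= 25000 nM
- compound 2 `COc1ccc(/C=N/NC(=O)c2cn(C3CC3)c3cc(N/N=C/c4ccc(OC)cc4)c(F)cc3c2=O)cc1`: <= 25000 nM
- compound 3 `O=C(N/N=C/c1ccccc1[N+](=O)[O-])c1cn(C2CC2)c2cc(N/N=C/c3ccccc3[N+](=O)[O-])c(F)cc2c1=O`: <= 25000 nM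

In this assay compound 1 gives <= 25000 nM, which is a limit and not a number. For the measured compounds named here, the three measured compounds share the limit of <= 25000 nM in this assay, at which 3 of the 3 values shown sit, and so offer no measured step. Compound 4 `O=C(N/N=C/c1ccccc1)c1cn(C2CC2)c2cc(N3CCNCC3)c(F)cc2c1=O` differs from compound 1 on an aromatic carbon, ortho to a fluoro group, where piperazin-1-yl enters: a group of 6 heavy atoms (4 carbon, 2 nitrogen; one six-membered non-aromatic ring with 2 hetero atoms) in place of a group of 9 heavy atoms (7 carbon, 2 nitrogen; one six-membered aromatic ring of carbon only), on an aromatic carbon. Going by the values given here, with no measured step to draw on, no change beyond the scatter is expected in this assay, and no direction can be assigned. The expected step that the limit leaves unreadable from compound 1 to compound 4 is therefore estimated as small. For compound 4 the estimated value is 15000 nM, with an expected range from 4000 nM to 50000 nM.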

Compound 4, half-maximal inhibitory concentration: <= 25000 nM
Compound 4: a limit, no number; the forecaster's own chance of this, stated with the estimate: 35%; the middle value does not contradict the limit.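

In this assay compound 4 gives <= 25000 nM, a limit. For the compounds shown here, compound 1 also stands at a limit, so no step between compound 1 and compound 4 can be read: the limit of <= 25000 nM in this assay, at which 4 of the 4 values shown sit. The compounds shown leave open the size and direction of any difference among the four.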